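The source may report more compounds than this note shows. Statements on the series, on what has been measured and on what is new or still open speak of the compounds shown alone.

In a physicochemical assay for solubility, with a stated time of 3 days, at pH 2 (a lower number here means a less soluble compound, a higher number a more soluble compound), compound 1 `NC(=O)c1ccc2[nH]c(-c3ccc(OCCCN4CCCCC4)cc3)nc2c1` reaches only a limit of the assay, > 400000 nM. Compound 2 `COc1ccc(CN2CCC(CCOc3ccc(-c4nc5cc(C(N)=O)ccc5[nH]4)cc3)CC2)cc1` likewise gives a limit in this assay, > 400000 nM. What is known of the pair comes down to the limit of > 400000 nM in this assay, at which 2 of the 2 values shown sit. Compound 3 `CC(=O)N1CCC(CCOc2ccc(-c3nc4cc(C(N)=O)ccc4[nH]3)cc2)CC1` has not yet been measured; compared with compound 2 it carries acetyl in place of 4-methoxybenzyl on an amine nitrogen in a ring. Going by the values given here, no measured step between compounds is available to lean on, yet a downward step beyond the scatter is expected here, its size left open by the limits. The solubility of compound 3 in this assay is estimated at 150000 nM, between 20000 nM and 400000 nM. That means an expected step of an at least 2.6-fold lower number from compound 2 to compound 3 (0.42 log units; beyond the scatter).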

Compound 3, solubility: 87000 nM
For compound 3 the middle estimate is 1.7-fold (0.24 log units) above the measured one; low and high end bracket the measured number.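

Of the compounds shown, only compound 3 gives a number rather than a limit in this assay, so acetyl in place of 4-methoxybenzyl on the amine nitrogen in the ring now has a direction, with an at least 4.5-fold lower number from compound 2 to compound 3 (0.66 log units; beyond the scatter) as its step. Going to 1-acetylpiperidin-4-yl in place of (piperidin-1-yl)methyl reads the same way, with an at least 4.5-fold lower number from compound 1 to compound 3 (0.66 log units; beyond the scatter) as its step. Both steps give only a minimum size, since each starts from a limit: the limit of > 400000 nM in this assay, at which 2 of the 3 values shown sit.

On these data alone, how large either step really is remains open. So does what a methyl, a benzoyl or a longer acyl chain on that nitrogen would give.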